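Compound 3 against the high clearance of compound 2

The compounds below may be only part of what the source reports. "The series", "measured", "known", "first", "only" and "open" are said of these compounds alone.

Compound 1 `O=C(NCCCCn1cccn1)c1cccc(C2SCC(=O)N2c2ccccn2)c1`: 88.9 mL.min-1.g-1
Compound 2 `O=C(NCCCCc1ccccc1)c1cccc(C2SCC(=O)N2c2ccccn2)c1`: 492 mL.min-1.g-1
Compound 3 `O=C(NCCCCc1ccccc1)c1cccc(C2SCC(=O)N2c2ccc(C3CC3)cc2)c1`: not yet measured

For the measured compounds named here, in an ADME assay on microsomes from liver (Canis lupus familiaris) for metabolic stability, read by LC-MS, using NADPH, with a stated time of 10 min, tested at 0.1 uM (a lower number here means slower removal, a higher number faster removal of the compound), compound 2 gives 492 mL.min-1.g-1, the highest of the two numbers, with compound 1 as its only neighbour. Compound 3 carries 4-cyclopropylphenyl in place of pyridin-2-yl on an amide-type nitrogen in a ring.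

Going by the values given here, no measured step touches this place. Among the compounds with values here, the one step available, a 5.5-fold higher number from compound 1 to compound 2 (0.74 log units; beyond the scatter), came with phenyl in place of 1H-pyrazol-1-yl on a saturated chain carbon. It bears only loosely, as a case where a ring of carbon only entered in place of a ring holding nitrogen. A higher number is therefore expected in this assay, though a smaller move than that one, and the size remains uncertain. The expected change is a 2.2-fold higher number from compound 2 to compound 3 (0.35 log units; beyond the scatter). For compound 3 the estimated value is 1100 mL.min-1.g-1, with an expected range of 450 mL.min-1.g-1 to 2700 mL.min-1.g-1.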

Compound 3, intrinsic clearance in microsomes: 1080 mL.min-1.g-1
Estimate against measurement, compound 3: 1.0-fold (0.01 log units) above, and the stated range covers the measured number.
By their numbers in this assay, from the lowest: compound 1; then compound 2; then compound 3.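

In this assay the place on the amide-type nitrogen in a ring now has its own measured step: 4-cyclopropylphenyl in place of pyridin-2-yl gives a 2.2-fold higher number from compound 2 to compound 3 (0.34 log units; beyond the scatter) and the number still rises from an already high start, so this place moves clearance as well as the group on the chain. Both steps now in hand, a 5.5-fold higher number from compound 1 to compound 2 (0.74 log units; beyond the scatter) and the new one, bring in a ring of carbon only where a ring holding nitrogen stood, and no compound shown goes against that direction, though the base is only two steps at two different places. Nothing available bears on what lies behind the rise. For the compounds shown here, the single change removes the ring nitrogen and adds the three-membered ring together, which leaves open how much of the step belongs to each part, and plain phenyl at this place would separate them. Also open, on these data alone, is whether a carboxylic acid or a morpholine in place of the cyclopropyl would bring the number back towards compound 1 at 88.9 mL.min-1.g-1 while the phenyl chain stays.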